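Removing a Protecting Group from a Sulfonamide Series

The source may report more compounds than this note shows. Statements on the series, on what has been measured and on what is new or still open speak of the compounds shown alone.

Two compounds share a sulfonamide core. Compound 1 `O=C(c1ccccn1)N1CCC(NS(=O)(=O)c2cc(S(=O)(=O)c3ccccc3)ccc2C(F)(F)F)CC1` gives 230 nM in an assay on U2OS cells for inhibition of secreted frizzled-related protein 1 (Homo sapiens), read by a luciferase reporter, with a stated time of 18 h; on this read-out lower numbers stand for an effect already at smaller amounts and higher numbers for an effect only at larger amounts of compound. Compound 2 `CC(C)(C)OC(=O)N1CCC(CC(=O)N2CCC(NS(=O)(=O)c3cc(S(=O)(=O)c4ccccc4)ccc3C(F)(F)F)CC2)CC1` gives 400 nM in this assay, the higher of the two numbers, though its gap to compound 1 lies within the usual scatter. Compound 3 `O=C(CC1CCNCC1)N1CCC(NS(=O)(=O)c2cc(S(=O)(=O)c3ccccc3)ccc2C(F)(F)F)CC1` differs from compound 2 by hydrogen in place of tert-butoxycarbonyl on an amine nitrogen in a ring. Within the data shown here, no measured pair shows such a change here, so the step is expected to be small: from a 1.1-fold lower number from compound 2 to compound 3 (0.06 log units; within the scatter), no clear shift beyond the scatter. Compound 3 is therefore estimated at 350 nM, within a range from 120 nM to 1200 nM.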

Compound 3, half-maximal effective concentration: 210 nM
Estimate against measurement, compound 3: 1.7-fold (0.22 log units) above; low and high end bracket the measured number.
By their numbers in this assay, from the lowest: compounds 3, 1 and 2 (each within the scatter of the next).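

Replacing tert-butoxycarbonyl with hydrogen on the amine nitrogen in the ring gives a 1.9-fold lower number from compound 2 to compound 3 (0.28 log units; within the scatter) in this assay, so this large group can go without a clear shift. Placing (piperidin-4-yl)methyl instead of pyridin-2-yl on the carbonyl carbon gives a 1.1-fold lower number from compound 1 to compound 3 (0.04 log units; within the scatter) and also shows no clear shift. No measurement here offers an explanation for these results.

From the compounds shown here alone, it remains open whether another group on that ring nitrogen, such as methyl or acetyl, would move the number beyond the scatter.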